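Methyl to ethyl on the amide of compound 1

The compounds below may be only part of what the source reports. "The series", "measured", "known", "first", "only" and "open" are said of these compounds alone.

Measured compounds:
- compound 1, `CCC1C(=O)N(C)c2cnc(-n3ccc4cc(C(=O)NC)ccc43)nc2N1c1ccn(C)n1`: 6330 nM
- compound 2, `CCC1C(=O)N(C)c2cnc(Nc3ccc(S(=O)(=O)NCCO)cc3)nc2N1c1ccn(C)n1`: "not active" (no number reported)
- compound 3, `CCNC(=O)c1ccc2c(ccn2-c2ncc3c(n2)N(C2CCCC2)[C@H](CC)C(=O)N3C)c1`: 418 nM

In a functional assay on HeLa cells (Homo sapiens) for antiproliferative activity, read by CCK-8 assay, with a stated time of 72 h (on this read-out lower numbers stand for stronger inhibition of growth and higher numbers for weaker inhibition of growth), compound 1 gives 6330 nM, the highest of the two numbers reported. Compound 3 gives 418 nM in this assay, a lower number, and the gap between compound 1 and compound 3 lies beyond the usual scatter; compound 3 differs from compound 1 in more than one place, so the two values alone cannot be tied to a single change. Compound 2 is reported as "not active" (no number reported) in this assay, without a number.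

Compound 4, `CCNC(=O)c1ccc2c(ccn2-c2ncc3c(n2)N(c2ccn(C)n2)C(CC)C(=O)N3C)c1`, has not yet been measured. It differs from compound 1 in one place: methyl in place of hydrogen on a saturated chain carbon bound to an amide-type nitrogen. Going by the values given here, the same kind of amide end, ethylcarbamoyl, is found in compound 3, but compound 3 also carries a different group on the amide-type nitrogen of the shared core, so no step isolates the effect of this single change. With nothing else to go on, the step from compound 1 to compound 4 is expected to stay within the scatter, a 1.3-fold lower number from compound 1 to compound 4 (0.10 log units; within the scatter), with no clear direction. Compound 4 is therefore estimated at 5000 nM in this assay, within a range from 2000 nM to 15000 nM.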

Compound 4, concentration for 50% growth inhibition: 11100 nM
For compound 4 the middle estimate is 2.2-fold (0.35 log units) below the measured one, and the stated range covers the measured number.
By their numbers in this assay, from the lowest: compound 3; then compounds 1 and 4 (each within the scatter of the next).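

In this assay, going by these compounds alone, the change from methylcarbamoyl to ethylcarbamoyl gives a 1.8-fold higher number from compound 1 to compound 4 (0.24 log units; within the scatter) and is the first comparison here that isolates a single place, so at this end of the molecule the added methyl leaves the two compounds indistinguishable on this read-out. Compound 3 also ends in ethylcarbamoyl but carries a different group on the amide-type nitrogen of the shared core; it gives 418 nM against 11100 nM for compound 4, so the ethylcarbamoyl end alone does not bring the lower number seen with compound 3. No available measurement explains why this change has so little effect on growth inhibition.

Going by these compounds, how a longer chain such as propyl, a ring such as cyclopropyl or a carboxylic acid in place of the amide would read at this end remains open. Also open, on these data alone, is whether methylcarbamoyl and ethylcarbamoyl would still read alike with the group of compound 3 on the amide-type nitrogen of the shared core.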